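The source may hold more compounds than are shown below. What is called first, only, known or untested is meant among the compounds shown, and "the series" means these compounds.

Working notes on the series. The shared core carries an acylguanidine and a methylsulfonyl group; the variable part is the group on the sulfur. Compound 1 `Cc1cc(SC(C)(C)C)c(S(C)(=O)=O)cc1C(=O)N=C(N)N` carries a tert-butyl there, and in a functional assay for inhibition of sodium/hydrogen exchanger (Oryctolagus cuniculus) (a lower number here means a stronger inhibitor, a higher number a weaker inhibitor), compound 1 gives 22 nM. Compound 2 `Cc1cc(Sc2ccccc2Cl)c(S(C)(=O)=O)cc1C(=O)N=C(N)N` carries a 2-chlorophenyl; in this assay compound 2 gives 14 nM. The step of a 1.6-fold lower number from compound 1 to compound 2 (0.20 log units; within the scatter) is the only measured one, and it lies within the scatter, so compound 2 holds the lowest of the two numbers without being separable from compound 1.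

Compound 3 `Cc1cc(Sc2ccncc2)c(S(C)(=O)=O)cc1C(=O)N=C(N)N` differs from compound 2 by pyridin-4-yl in place of 2-chlorophenyl on a sulfur. Going by the values given here, no measured pair tests an aromatic ring exchanged for another aromatic ring on this sulfur; the one step available, from compound 1 to compound 2, replaces a saturated group by an aromatic ring and stays within the scatter. The bearing on compound 3 is therefore indirect, and nothing in the measured numbers supports a step beyond the scatter in this assay in either direction.

Compound 3 is expected to give about 25 nM in this assay, with a range from 9 nM to 70 nM. The step this estimate implies, a 1.8-fold higher number from compound 2 to compound 3 (0.25 log units; within the scatter), is expected to remain within the scatter.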

Compound 3, half-maximal inhibitory concentration: 13 nM
Compound 3: middle estimate off by 1.9-fold (0.28 log units), on the high side; low and high end bracket the measured number.
By their numbers in this assay, from the lowest: compounds 3, 2 and 1 (each within the scatter of the next).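

Going by these compounds alone, the exchange of one aromatic ring for another on this sulfur, read in this assay as a 1.1-fold lower number from compound 2 to compound 3 (0.03 log units; within the scatter), tests for the first time a ring with one hetero atom and a hydrogen-bond acceptor against a carbon-only ring carrying chlorine, and this difference does not separate the two compounds. The step of a 1.7-fold lower number from compound 1 to compound 3 (0.23 log units; within the scatter) also stays within the scatter, so tert-butyl, 2-chlorophenyl and pyridin-4-yl now give three numbers that cannot be told apart, and across these compounds neither a saturated group nor either aromatic ring on this sulfur yields a step beyond the scatter. No measurement at hand accounts for how closely these numbers agree.

As far as these compounds go, it remains open whether a group of another kind on this sulfur, such as an amine, a carboxylic acid or a longer alkyl chain, would produce a step beyond the scatter. Also open, from the compounds shown here alone, is whether pyridin-3-yl or pyridin-2-yl would read like pyridin-4-yl, and whether an unsubstituted phenyl would read like 2-chlorophenyl.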